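Switching the thiazole isomer on the biaryl imidazoline core

The source may hold more compounds than are shown below. What is called first, only, known or untested is meant among the compounds shown, and "the series" means these compounds.

Measured compounds:
compound 1, `c1c[nH]c(-c2ccccc2OCC2=NCCN2)c1`: 1.26 nM
compound 2, `c1ccc(-c2ccoc2)c(OCC2=NCCN2)c1`: 0.501 nM
compound 3, `Cc1csc(-c2ccccc2OCC2=NCCN2)n1`: 25.1 nM

In a functional assay for activation of Alpha-1A adrenergic receptor (Homo sapiens), read by calcium flux (on this read-out higher numbers stand for an effect only at larger amounts of compound and lower numbers for an effect already at smaller amounts), compound 3 stands highest of the three, with a 20-fold higher number from compound 1 to compound 3 (1.30 log units; beyond the scatter) and a 50-fold higher number from compound 2 to compound 3 (1.70 log units; beyond the scatter) both beyond the scatter. Compound 4, `Cc1cnsc1-c1ccccc1OCC1=NCCN1`, differs from compound 3 by 4-methyl-1,2-thiazol-5-yl in place of 4-methyl-1,3-thiazol-2-yl on an aromatic carbon, the same atoms joined differently. For the measured compounds named here, no measured step swaps one thiazole isomer for another; the steps bearing on it are only those from compound 1 and compound 2 to compound 3, which show that the identity of the five-membered ring can move this assay by a large amount. The direction for compound 4 is therefore uncertain, and the step of a 1.3-fold lower number from compound 3 to compound 4 (0.10 log units; within the scatter) is estimated to be small. Compound 4 is expected to give about 20 nM, between 2.5 nM and 160 nM.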

Compound 4, half-maximal effective concentration: 12.6 nM
Estimate against measurement, compound 4: 1.6-fold (0.20 log units) above; measured number inside the range.
By their numbers in this assay, from the lowest: compound 2; then compound 1; then compounds 4 and 3 (each within the scatter of the next).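

In this assay the two thiazole isomers cannot be told apart, with a 2.0-fold lower number from compound 3 to compound 4 (0.30 log units; within the scatter) as the step between them. Compound 4 also stays clear of both other rings, with a 25-fold higher number from compound 2 to compound 4 (1.40 log units; beyond the scatter) and a 10-fold higher number from compound 1 to compound 4 (1.00 log units; beyond the scatter) as its steps, so on this position the gap from the furan and the pyrrole holds for both arrangements of the thiazole atoms. Nothing measured here accounts for that gap. On these data alone, whether the methyl matters stays open, as does the effect of an amine or a carboxylic acid in its place on either thiazole.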